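The source may hold more compounds than are shown below. What is called first, only, known or untested is meant among the compounds shown, and "the series" means these compounds.

Among the measured compounds shown here, in a functional assay on CCRF-CEM cells (Homo sapiens) for inhibition, read by cell counting, with a stated time of 3 days (a lower number here means a stronger inhibitor, a higher number a weaker inhibitor), compound 2 `C=C(Br)C(=O)Nc1cccc(-c2cn3nc(-c4ccc(CC)cc4)sc3n2)c1` gives 3400 nM, the lowest of the three numbers measured so far. Compound 1 `CCc1ccc(-c2nn3cc(-c4cccc(N)c4)nc3s2)cc1` gives 22000 nM in this assay, and compound 3 `Nc1cccc(-c2cn3nc(Cc4ccc(Cl)cc4)sc3n2)c1` gives 42000 nM. For the measured compounds named here, the only single-place step measured, a 6.5-fold lower number from compound 1 to compound 2 (0.81 log units; beyond the scatter), concerns the group on the nitrogen on an aromatic ring, and compound 4 keeps that group unchanged. Compound 4 `C=C(Br)C(=O)Nc1cccc(-c2cn3nc(-c4cccc(OC)c4)sc3n2)c1` differs from compound 2 by 3-methoxyphenyl in place of 4-ethylphenyl on an aromatic carbon. Going by the values given here, no measured pair changes the group at that place, so nothing in the data bears directly on this replacement, and no step beyond the scatter is expected. The expected step in this assay is a 1.3-fold higher number from compound 2 to compound 4 (0.12 log units; within the scatter). Compound 4 is therefore estimated at 4500 nM in this assay, with a range from 1500 nM to 14000 nM.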

Compound 4, half-maximal inhibitory concentration: 1200 nM
Compound 4: the middle estimate sits 3.8-fold (0.57 log units) above what was measured; measured number outside the range, below it.
By their numbers in this assay, from the lowest: compound 4; then compound 2; then compounds 1 and 3 (each within the scatter of the next).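

Among the compounds shown here, this is the first measured change at this place, the aromatic carbon next to the ring nitrogen and next to the ring sulfur, and in this assay it gives a 2.8-fold lower number from compound 2 to compound 4 (0.45 log units; beyond the scatter) with the (1-bromoethenyl)carbonyl group held constant. The number therefore responds to the aryl group here, and 3-methoxyphenyl gives the lower number of the two. Nothing at hand explains this difference.

The compounds shown leave open whether the methoxy group or its ring position drives the step; 4-methoxyphenyl or 3-ethylphenyl would separate the two. From the compounds shown here alone, whether the step holds on the free amine also stays open.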